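A few compounds are considered here, and "the series" means these few. Any claim that something is new, unique, unknown or untested is made for them only; others in the source may bear on it.

Compound 1 `COC(=O)[C@@]1(C)CCC=C2[C@@H]1CC[C@@H](C)[C@]2(C)Cc1c[nH]c2c(Br)cccc12` and compound 2 `COC(=O)[C@@]1(C)CCC=C2[C@@H]1CC[C@@H](C)[C@]2(C)Cc1c[nH]c2c(Cl)cccc12` share one core, while compound 3 `COC(=O)[C@@]1(C)CC[C@@H]2C3=C1CC[C@@H](C)[C@]3(C)C[C@@H]1c3cccc(Br)c3N[C@H]21` and compound 4 `COC(=O)[C@@]1(C)CC[C@@H]2C3=C1CC[C@@H](C)[C@]3(C)C[C@@H]1c3cccc(Cl)c3N[C@H]21` share another; the difference between the two cores is not broken down here. In a functional assay on HBL-100 cells (Homo sapiens) for inhibition, read by sulforhodamine B assay, with a stated time of 48 h (on this read-out higher numbers stand for weaker inhibition of growth and lower numbers for stronger inhibition of growth), compound 1 gives 18000 nM and compound 2 gives 19000 nM, so the change chloro in place of bromo on an aromatic carbon produced a 1.1-fold higher number from compound 1 to compound 2 (0.02 log units; within the scatter). In this assay compound 3 gives 40000 nM, the highest of the three numbers. Compound 4 carries chloro in place of bromo on an aromatic carbon, the same kind of change, now on a fused or bridged system of five rings rather than two. Because a 1.1-fold higher number from compound 1 to compound 2 (0.02 log units; within the scatter) lay within the scatter, compound 4 is expected to show a step of a 1.1-fold higher number from compound 3 to compound 4 (0.02 log units; within the scatter) in this assay. Compound 4 is therefore estimated at 42000 nM, with a range from 20000 nM to 85000 nM.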

Compound 4, concentration for 50% growth inhibition: 52000 nM
Estimate against measurement, compound 4: 1.2-fold (0.09 log units) below; measured number inside the range.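

In this assay, putting chloro in place of bromo on the second core gave a 1.3-fold higher number from compound 3 to compound 4 (0.11 log units; within the scatter) and so again left the number within the scatter. The two steps do not differ, so this change carried from the core of compound 1 to the core of compound 3 with no visible difference in size: the same change on two cores in this assay, a 1.1-fold higher number (0.02 log units; within the scatter) from compound 1 to compound 2 and a 1.3-fold higher number (0.11 log units; within the scatter) from compound 3 to compound 4, 1.2-fold (0.09 log units) apart, within the scatter of two such steps. This rests on just two pairs in one cell line, and it shows nothing about how the two cores differ from each other or whether the same agreement would hold on any other core.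

The compounds shown leave open what a smaller halogen such as fluoro, or a group of another kind such as an amine or a carboxylic acid, would do on that aromatic carbon. They also leave open whether such a change would carry between the two cores in the same way.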